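The source may hold more compounds than are shown below. What is called first, only, known or untested is meant among the compounds shown, and "the series" means these compounds.

Measured so far:
compound 1, `COc1ccc(F)cc1CNCCCNc1ccnc2cc(Oc3ccc(F)cc3)ccc12`, 6600 nM in an ADME assay on HepG2 cells (Homo sapiens) for cytotoxicity, read by luminescence, CellTiter-Glo and ATP content, with a stated time of 72 h; on this read-out higher numbers stand for an effect only at larger amounts of compound and lower numbers for an effect already at smaller amounts
compound 2, `Fc1ccc(Oc2ccc3c(NCCCNCc4ccco4)ccnc3c2)cc1`, 16000 nM in this assay
compound 3, `COc1cccc(CNCCCNc2ccnc3cc(Oc4ccc(F)cc4)ccc23)c1O`, 11000 nM in this assay

Compound 1 gives the lowest of the three numbers in this assay. Its nearest neighbour is compound 3, with a 1.7-fold higher number from compound 1 to compound 3 (0.22 log units; within the scatter), a difference within the scatter; the furthest is compound 2, with a 2.4-fold higher number from compound 1 to compound 2 (0.38 log units; beyond the scatter), a modest step beyond the scatter. Between compound 2 and compound 3 the difference is a 1.5-fold lower number from compound 2 to compound 3 (0.16 log units; within the scatter), again within the scatter. All three measured steps exchange the group on a saturated chain carbon bound to an amine nitrogen and leave the rest of the core untouched.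

Compound 4, `COc1ccc(F)cc1CNCCCNc1ccnc2cc(Cc3cc(C)cc(C)c3)ccc12`, differs from compound 1 elsewhere: 3,5-dimethylbenzyl in place of 4-fluorophenoxy on an aromatic carbon. For the measured compounds named here, none of the measured steps touches this aromatic carbon, so no measured step bears directly on the change, and the expectation rests on compound 1 alone. Since the measured changes at the other end of the molecule moved the number only modestly, compound 4 is expected to stay near compound 1, with an estimated step of a 1.3-fold lower number from compound 1 to compound 4 (0.12 log units; within the scatter) in this assay. The estimate for compound 4 is 5000 nM, within a range of 1800 nM to 14000 nM.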

Compound 4, half-maximal effective concentration: 940 nM
Estimate against measurement, compound 4: 5.3-fold (0.73 log units) above, and the stated range ends above it.
By their numbers in this assay, from the lowest: compound 4; then compounds 1, 3 and 2 (each within the scatter of the next, the first and the last beyond it).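

In this assay, exchanging 4-fluorophenoxy for 3,5-dimethylbenzyl on this aromatic carbon gives a 7.0-fold lower number from compound 1 to compound 4 (0.85 log units; beyond the scatter), a larger step than any measured among compounds 1, 2 and 3. This shows that the number responds to a change at this position, and further than it did to any of the exchanges on the saturated chain carbon bound to an amine nitrogen. Nothing available explains why the number moves with this change.

From the compounds shown here alone, compound 4 alters the link to the ring, the fluorine and the methyl groups all at once, so their separate contributions remain open; an unsubstituted benzyl group or a 3,5-dimethylphenoxy group would bear on that question. Going by these compounds, it also remains open whether the step holds when furan-2-yl or 2-hydroxy-3-methoxyphenyl replaces 5-fluoro-2-methoxyphenyl on the chain.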